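A few compounds are considered here, and "the series" means these few. Any claim that something is new, unique, unknown or untested is made for them only; others in the source may bear on it.

Of the compounds shown here, three have been measured in a functional assay on DLD-1 cells (Homo sapiens) for antiproliferative activity, read by CellTiter-Glo, with a stated time of 72 h; a lower number here means a stronger inhibitor, a higher number a weaker inhibitor.
Compound 1 `Cc1cc(C)c(S(=O)(=O)N2CCC(N3CCC(CCO)CC3)CC2)c(C)c1` gives 19 nM in this assay.
Compound 2 `Cc1cc(C)c(S(=O)(=O)N2CCC(N3CCC(C(C)C)CC3)CC2)c(C)c1` gives 0.3 nM in this assay.
Compound 3 `Cc1cc(C)c(S(=O)(=O)N2CCC(c3ccccc3)CC2)c(C)c1` reaches only the limit of this assay, > 5000 nM.

Compound 2 stands lowest of the two numbers shown; its nearest neighbour is compound 1, with a 63-fold lower number from compound 1 to compound 2 (1.80 log units; beyond the scatter). The third value, that of compound 3, is a limit and not a number (the limit of > 5000 nM in this assay, at which 1 of the 3 values shown sits).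

Compound 4 `Cc1cc(C)c(S(=O)(=O)N2CCC(N3CCC(Cc4ccccc4)CC3)CC2)c(C)c1` has not yet been measured. It differs from compound 2 in one place: benzyl in place of isopropyl on a saturated ring carbon. Of the measured steps, a 63-fold lower number from compound 1 to compound 2 (1.80 log units; beyond the scatter) is the one that touches the same position, and it was a large change. The steps of an at least 260-fold higher number from compound 1 to compound 3 (2.42 log units; beyond the scatter) and an at least 16000-fold higher number from compound 2 to compound 3 (4.22 log units; beyond the scatter) exchange the whole piperidinyl group for phenyl and say little about a change within that ring. Within the data shown here, no measured step exchanges isopropyl for benzyl, so the direction is open; a step within the scatter or a small rise in the number is expected. Compound 4 is expected to give about 1 nM, in the range 0.2 nM to 8 nM. That estimate means a 3.3-fold higher number from compound 2 to compound 4 (0.52 log units; beyond the scatter).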

Compound 4, half-maximal inhibitory concentration: 3.5 nM
For compound 4 the middle estimate is 3.5-fold (0.54 log units) below the measured one; the measured number falls inside the stated range.
By their numbers in this assay, from the lowest: compound 2; then compound 4; then compound 1. At a limit, above all of these: compound 3.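

At this saturated ring carbon, three ring bonds from the ring nitrogen, the position proves sensitive to a change between two groups that both carry no hydrogen-bond donors or acceptors: in this assay, exchanging isopropyl for benzyl gives a 12-fold higher number from compound 2 to compound 4 (1.07 log units; beyond the scatter) and so costs a large part of the strength of compound 2. The same position still accepts a six-membered aromatic ring at the end of a side chain, since the step to benzyl from 2-hydroxyethyl gives a 5.4-fold lower number from compound 1 to compound 4 (0.73 log units; beyond the scatter) and places benzyl between the two other groups on this carbon. Nothing shown here gives a reason for either step.

The compounds shown do not separate the effect of the aromatic ring from that of the longer reach of benzyl, and a cyclohexylmethyl group, or a phenyl set directly on this ring carbon, would bear on that question. On these data alone, how far the order of the three groups extends also remains open, for instance to a tert-butyl or cyclopropyl group or to a side chain ending in an amine or a carboxylic acid.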